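A Methyl on the Ring Amine of Compound 2

A few compounds are considered here, and "the series" means these few. Any claim that something is new, unique, unknown or untested is made for them only; others in the source may bear on it.

Compound 1 `CCn1cc(-c2nc3ccccc3[nH]2)c(=O)c2cc(F)c(N3CCNCC3)cc21` was tested in a functional assay on A549 cells (Homo sapiens) for cytotoxicity, read by sulforhodamine B assay, with a stated time of 48 h (on this read-out lower numbers stand for stronger inhibition and higher numbers for weaker inhibition), and gave 4700 nM. Compound 2 `CCn1cc(-c2nc3ccc(N)cc3[nH]2)c(=O)c2cc(F)c(N3CCNCC3)cc21` carries an amino group in place of a hydrogen on an aromatic carbon. In this assay compound 2 reached only the limit of > 10000 nM. That step, an at least 2.1-fold higher number from compound 1 to compound 2 (0.32 log units; beyond the scatter), rests on (the limit of > 10000 nM in this assay, at which 1 of the 2 values shown sits). Compound 3 `CCn1cc(-c2nc3ccc(N)cc3[nH]2)c(=O)c2cc(F)c(N3CCN(C)CC3)cc21` differs from compound 2 by methyl in place of hydrogen on an amine nitrogen in a ring. Among the compounds with values here, no measured step touches this change, and the one known step concerns a different place, so no shift beyond the scatter is expected and compound 3 is estimated at 15000 nM (from 7000 nM to 40000 nM), an expected step that the limit leaves unreadable from compound 2 to compound 3.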

Compound 3, half-maximal inhibitory concentration: > 10000 nM
Compound 3: only a limit was reported; the forecaster's own chance of this, stated with the estimate: 70%; the middle value is on the limit's open side.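

No step can be read between compound 2 and compound 3, as each gives only a limit in this assay: the limit of > 10000 nM in this assay, at which 2 of the 3 values shown sit. As far as these compounds go, whether 4-methylpiperazin-1-yl in place of piperazin-1-yl shifts the number in this assay stays open.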